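Swapping the anilide aryl in a prostaglandin D2 receptor series

This account rests on a few compounds, and the source may have more. Where it says the series, first, only, none or still open, it means among the compounds named here.

Of the compounds shown here, two have been measured so far in an assay on CHO cells for displacement of a labelled ligand from prostaglandin D2 receptor (Mus musculus), read by scintillation counting, with a stated time of 60 min; on this read-out higher numbers stand for weaker inhibition and lower numbers for stronger inhibition. Compound 1, `Cc1cc(OC[C@@H]2CN(C)c3ccccc3O2)ccc1C(=O)Nc1ccc(F)c(CC(=O)O)c1`, gives 15 nM. Compound 2, `Cc1cc(CC(=O)O)cc(NC(=O)c2ccc(OC[C@@H]3CN(C)c4ccccc4O3)cc2Cl)c1`, gives 12 nM. Compound 2 holds the lower of the two numbers, but its gap to compound 1 falls within the scatter of repeated measurements, so the two cannot be ordered on this evidence.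

Compound 3, `CN1C[C@@H](COc2ccc(C(=O)Nc3ccc(F)c(CC(=O)O)c3)c(Cl)c2)Oc2ccccc21`, has not yet been measured. It departs from compound 2 in one place: 3-(carboxymethyl)-4-fluorophenyl in place of 3-(carboxymethyl)-5-methylphenyl on an amide-type nitrogen. The amide nitrogen of compound 2 therefore carries the same aryl group that is already present in compound 1.

Among the measured compounds shown here, no directly comparable step between measured compounds exists, so the direction and size of this change must be judged from the two values alone. Since compound 1, which already bears the entering group, gives 15 nM and sits within the scatter of compound 2, the expected step of a 1.2-fold higher number from compound 2 to compound 3 (0.07 log units; within the scatter) is small and may not exceed the scatter at all. Compound 3 is accordingly estimated at 14 nM, within a range of 5 nM to 40 nM.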

Compound 3, inhibition constant: 25 nM
Estimate against measurement, compound 3: 1.8-fold (0.25 log units) below, and the stated range covers the measured number.
By their numbers in this assay, from the lowest: compounds 2, 1 and 3 (each within the scatter of the next, the first and the last beyond it).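

With chloro held constant, 3-(carboxymethyl)-4-fluorophenyl in place of 3-(carboxymethyl)-5-methylphenyl on the amide-type nitrogen gives a 2.1-fold higher number from compound 2 to compound 3 (0.32 log units; beyond the scatter) in this assay, so this aryl swap is a single change whose modest step lies beyond the scatter. With 3-(carboxymethyl)-4-fluorophenyl held constant, chloro in place of methyl on an aromatic carbon gives a 1.7-fold higher number from compound 1 to compound 3 (0.22 log units; within the scatter) in this assay, and this step stays within the scatter, so the pair shows no readable effect of that change. Nothing at hand bears on what lies behind either step.

The aryl swap removes a methyl group and brings in a fluorine in one step, so the compounds shown do not assign the step to either, and an aryl group carrying the carboxymethyl chain alone would be needed to separate them. Also open, going by these compounds, is how this position would respond to a methoxy group or a nitrile on the aryl ring, or to a propanoic acid chain in place of the carboxymethyl chain.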